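The source may hold more compounds than are shown below. What is called first, only, known or untested is meant among the compounds shown, and "the series" means these compounds.

Three compounds of one shared core, which differs only in the substituent on the phenyl ring at the far end of the piperazine, have been tested in a functional assay on the whole organism (strain CD-1) with Mus musculus as the target, in the maximal electroshock model, with a stated time of 2 h; on this read-out lower numbers stand for an effect already at smaller amounts and higher numbers for an effect only at larger amounts of compound. Compound 1, `CC1(c2ccccc2)CC(=O)N(CC(=O)N2CCN(c3ccccc3F)CC2)C1=O`, is reported in this assay as "not active" (no number reported), with no number given. Compound 2, `CC1(c2ccccc2)CC(=O)N(CC(=O)N2CCN(c3ccc(Cl)cc3)CC2)C1=O`, is likewise reported in this assay as "not active" (no number reported), again without a number. Going by the values given here, compound 3, `Cc1cccc(N2CCN(C(=O)CN3C(=O)CC(C)(c4ccccc4)C3=O)CC2)c1`, is the only member of the set for which a dose is stated: in this assay compound 3 gives 300 mg/kg. On the numbers shown, compound 3 therefore stands alone; the other two entries offer no figure to compare it with.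

The next compound, compound 4, `CC1(c2ccccc2)CC(=O)N(CC(=O)N2CCN(c3cccc(Cl)c3)CC2)C1=O`, has not yet been measured. Compared with compound 3 the change is chloro in place of methyl on an aromatic carbon; cut one bond further out, it reads 3-methylphenyl to 3-chlorophenyl, the new group sitting meta to a large group. Among the compounds with values here, no step between two measured compounds is available to guide this change, so the expectation rests on compound 3 alone and on the fact that compound 2, which also carries a chloro on that ring, gave "not active" (no number reported) without a number.

The step of a 1.3-fold higher number from compound 3 to compound 4 (0.12 log units; within the scatter) is expected to be small, if anything toward larger doses. Compound 4 is thus estimated at 400 mg/kg, with a range from 150 mg/kg to 1000 mg/kg.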

Compound 4, minimum effective dose: 300 mg/kg
Beside the measured number, compound 4's estimate is 1.3-fold (0.12 log units) above it, within the range that was stated.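

In this assay, putting chloro in place of methyl on this aromatic carbon gives no change at the digits printed from compound 3 to compound 4 (within the scatter), so at this position, meta to a large group, the two groups cannot be told apart on this read-out. It also gives the set its first number for a chlorinated ring: compound 2, with its chloro at another place on the phenyl ring, is reported as "not active" (no number reported), whereas compound 4 gives 300 mg/kg, so carrying a chloro on this ring does not by itself go with an entry without a number. Nothing measured here accounts for the methyl and chloro compounds reading alike.

With only two numbers in the set, the compounds shown leave open whether any group on this carbon would move the dose beyond the usual scatter, for example a methoxy group, an amine or a carboxylic acid. They also leave open whether a methyl group at the places occupied by the fluoro of compound 1 or the chloro of compound 2 would yield a number at all.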